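Adding a Second Chloro Group to Compound 1

The source may hold more compounds than are shown below. What is called first, only, known or untested is meant among the compounds shown, and "the series" means these compounds.

Measured compounds:
Compound 1 `CC1=C(/C=C/C(=O)/C=C/c2ccc(Cl)cc2)C(C)(C)CCC1`: 9500 nM
Compound 2 `CC1=C(/C=C/C(=O)/C=C/c2ccc(C#N)cc2)C(C)(C)CCC1`: 11900 nM
Compound 3 `CC1=C(/C=C/C(=O)/C=C/c2ccccc2C)C(C)(C)CCC1`: 44100 nM

In a functional assay on PC-3 cells (Homo sapiens) for cytotoxicity, read by sulforhodamine B assay, with a stated time of 48 h (on this read-out lower numbers stand for stronger inhibition and higher numbers for weaker inhibition), compound 1 gives the lowest of the three numbers. Compound 2 sits close by, with a 1.3-fold higher number from compound 1 to compound 2 (0.10 log units; within the scatter). Compound 3 lies furthest off, with a 4.6-fold higher number from compound 1 to compound 3 (0.67 log units; beyond the scatter).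

Compound 4 `CC1=C(/C=C/C(=O)/C=C/c2ccc(Cl)c(Cl)c2)C(C)(C)CCC1` differs from compound 1 by chloro in place of hydrogen on an aromatic carbon. Of the measured steps, the exchange of one ring substituent for another in compound 2 bears most directly, and it stayed within the scatter; the larger change in compound 3 gave only a modest rise. A second chloro group is therefore expected to leave the number near that of compound 1, so that a 1.2-fold lower number from compound 1 to compound 4 (0.07 log units; within the scatter) is expected. For compound 4 the estimate is 8000 nM, within 3000 nM to 20000 nM.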

Compound 4, half-maximal inhibitory concentration: 35500 nM
For compound 4 the middle estimate is 4.4-fold (0.65 log units) below the measured one, outside the stated range (above it).
By their numbers in this assay, from the lowest: compounds 1 and 2 (each within the scatter of the next); then compounds 4 and 3 (each within the scatter of the next).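

In this assay, this ring carbon, ortho to a chloro group and meta to a large group, does not tolerate the change silently: adding chloro in place of hydrogen gives a 3.7-fold higher number from compound 1 to compound 4 (0.57 log units; beyond the scatter). A single added heavy atom at this position thus moves the number beyond the scatter, whereas the exchange of chloro for cyano in compound 2 did not. Nothing available explains this rise.

The compounds shown leave open whether fluoro or methoxy at this position would raise the number as well. They also leave open how an amine there would behave.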